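Working notes: from compound 3 to compound 4

A few compounds are considered here, and "the series" means these few. Any claim that something is new, unique, unknown or untested is made for them only; others in the source may bear on it.

In a functional assay on A549 cells (Homo sapiens) for inhibition, read by MTT assay, with a stated time of 72 h (a lower number here means a stronger inhibitor, a higher number a weaker inhibitor), the measured compounds read:
- compound 1 `C=CC(=O)Nc1cc(Nc2nc3c(c(-c4cn(C)c5ccccc45)n2)CSCC3)c(OC)cc1N(C)CCN(C)C` gives 506 nM
- compound 2 `COc1cc(N(C)CCN(C)C)c(NC(=O)C=C(C)C)cc1Nc1nc2c(c(-c3cn(C)c4ccccc34)n1)CSCC2` gives 583 nM
- compound 3 `C/C=C\C(=O)Nc1cc(Nc2nc3c(c(-c4cn(C)c5ccccc45)n2)CSCC3)c(OC)cc1N(C)CCN(C)C` gives 6860 nM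

Compound 3 (6860 nM) carries the highest of the three numbers and is the weakest inhibitor of the set. Compound 4 `CC/C=C\C(=O)Nc1cc(Nc2nc3c(c(-c4cn(C)c5ccccc45)n2)CSCC3)c(OC)cc1N(C)CCN(C)C` turns its prop-1-en-1-yl into but-1-en-1-yl, and the change is methyl in place of hydrogen on a saturated chain carbon bound to a double-bonded chain carbon on the carbonyl side chain, with the rest of the structure untouched.

Among the measured compounds shown here, no measured step makes this exact change. The closest evidence comes from changes in the same group on the carbonyl carbon: a 14-fold higher number from compound 1 to compound 3 (1.13 log units; beyond the scatter) and a 12-fold higher number from compound 2 to compound 3 (1.07 log units; beyond the scatter) are large, whereas a 1.2-fold higher number from compound 1 to compound 2 (0.06 log units; within the scatter) stays within the scatter. These steps show that this group can matter, but they give no direction for an added methyl. No step beyond the scatter is therefore expected in this assay, though the uncertainty is wide.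

The expected change is a 1.2-fold higher number from compound 3 to compound 4 (0.07 log units; within the scatter) and it remains an estimate. Estimated for compound 4: 8000 nM (expected range 2500 nM to 20000 nM).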

Compound 4, half-maximal inhibitory concentration: 236 nM
Compound 4: middle estimate off by 34-fold (1.53 log units), on the high side; measured number outside the range, below it.
By their numbers in this assay, from the lowest: compound 4; then compounds 1 and 2 (each within the scatter of the next); then compound 3.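

In this assay, one methyl on the saturated chain carbon bound to a double-bonded chain carbon gives a 29-fold lower number from compound 3 to compound 4 (1.46 log units; beyond the scatter) on its own, so a single added carbon at this place can carry a large step. The earlier changes on the carbonyl carbon showed that this side chain matters, but none isolated this position. But-1-en-1-yl also moves ahead of the other two side chains, with a 2.5-fold lower number from compound 2 to compound 4 (0.39 log units; beyond the scatter) and a 2.1-fold lower number from compound 1 to compound 4 (0.33 log units; beyond the scatter) as modest steps, which makes compound 4 the strongest inhibitor of the four. No measurement shown here offers an explanation for the large step.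

The compounds shown leave open whether a longer chain such as pent-1-en-1-yl extends or reverses this step. They also leave open how a terminal amine or hydroxyl on the same chain would read.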